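This account rests on a few compounds, and the source may have more. Where it says the series, first, only, none or still open, it means among the compounds named here.

Measured compounds:

compound 1, `CC(=NNC(=S)Nc1ccccc1F)c1ccccn1`, 5 nM in a functional assay on U-87MG ATCC cells (Homo sapiens) for cytotoxicity, read by MTT assay, with a stated time of 48 h; a lower number here means a stronger inhibitor, a higher number a weaker inhibitor
compound 2, `CC(=NNC(=S)Nc1ccccc1)c1ccccn1`, 1.4 nM
compound 3, `C/C(=N\NC(=S)Nc1ccccc1F)c1ccccn1`, 5 nM

Compound 1 and compound 3 stand level in this assay: no change at the digits printed from compound 1 to compound 3 (within the scatter). The two cores differ only in how they are drawn, (the two compounds have the same atoms and bonds; at least one stereo element is drawn with a configuration in one of them and without one in the other: 1 of 1 stereo elements differ; a double bond is drawn without a configuration in compound 1 and E in compound 3), and the single thing that separates them is the fact that one of compounds 1 and 3 is drawn with a defined configuration and the other without, at the place where they differ. Together compound 1 and compound 3 carry the highest numbers of the three.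

From compound 1 to compound 2 the change is hydrogen in place of fluoro on an aromatic carbon, and it gives a 3.6-fold lower number from compound 1 to compound 2 (0.55 log units; beyond the scatter). Compound 2 therefore holds the lowest number of the three measured.

Not yet measured is compound 4, `C/C(=N\NC(=S)Nc1ccccc1)c1ccccn1`. It differs from compound 3 by hydrogen in place of fluoro on an aromatic carbon. Going by the values given here, this is the same change as the one from compound 1 to compound 2, made at the same place on the same kind of ring, and it occurs twice among the compounds here. Since compound 3 stands level with compound 1, as no change at the digits printed from compound 1 to compound 3 (within the scatter) shows, the step from compound 3 to compound 4 in this assay is expected to match the step already seen from compound 1 to compound 2, that is a 3.6-fold lower number from compound 1 to compound 2 (0.55 log units; beyond the scatter), so the expectation is a 3.3-fold lower number from compound 3 to compound 4 (0.52 log units; beyond the scatter). On that basis compound 4 is estimated at 1.5 nM, with the range 0.6 nM to 4 nM.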

Compound 4, half-maximal inhibitory concentration: 1.4 nM
The estimate for compound 4 lay 1.1-fold (0.03 log units) above the measured number, and the stated range covers the measured number.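

In this assay, hydrogen in place of fluoro on the aromatic carbon gives a 3.6-fold lower number from compound 3 to compound 4 (0.55 log units; beyond the scatter), and this step agrees with the one seen earlier: the same change on two cores in this assay, a 3.6-fold lower number (0.55 log units; beyond the scatter) from compound 1 to compound 2 and a 3.6-fold lower number (0.55 log units; beyond the scatter) from compound 3 to compound 4, 1.0-fold (0.00 log units) apart, within the scatter of two such steps

The two cores carrying the change also stand level without the fluoro, no change at the digits printed from compound 2 to compound 4 (within the scatter), so in this small set the drawn configuration of the double bond leaves no trace on either side of the change: the fact that one of compounds 2 and 4 is drawn with a defined configuration and the other without, at the place where they differ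

This shows that the step carries over between these two cores, but they have the same atoms and bonds and differ only in how one double bond is drawn, so the agreement is a narrow test and says nothing about a core that differs in its atoms or bonds.

From the compounds shown here alone, only fluoro and hydrogen appear at this place on the six-membered aromatic ring, so the outcome with a chlorine atom, a methoxy group or an amine there remains open. The Z form of the double bond also lies outside the compounds shown, as does any reading of this change in another cell line or assay.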